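The source may report more compounds than this note shows. Statements on the series, on what has been measured and on what is new or still open speak of the compounds shown alone.

Measured so far in a functional assay on MCF7 cells (Homo sapiens) for inhibition, read by MTT assay, with a stated time of 48 h, tested at 10 uM; a higher number here means more inhibition of growth at the concentration tested, a lower number less inhibition of growth
compound 1 `Cc1oc2c([C@H]3CCN(C)C[C@H]3O)c(O)cc(O)c2c(=O)c1C(O)c1ccc(F)c(Br)c1` gives 14%
compound 2 `Cc1oc2c([C@H]3CCN(C)C[C@H]3O)c(O)cc(O)c2c(=O)c1C(O)c1c(Cl)cccc1Cl` gives 33%

Compound 2 holds the higher of these two numbers, and its gap to compound 1 lies beyond the scatter. Next in line is compound 3 `COc1ccc(C(O)c2c(C)oc3c([C@H]4CCN(C)C[C@H]4O)c(O)cc(O)c3c2=O)cc1Br`, which differs from compound 2 as follows: 3-bromo-4-methoxyphenyl in place of 2,6-dichlorophenyl on a saturated chain carbon bound to an aromatic carbon and an oxygen on a saturated carbon and so carries 3-bromo-4-methoxyphenyl in place of 2,6-dichlorophenyl on the same saturated chain carbon.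

For the measured compounds named here, only one measured step bears on this change: a number 19 percentage points higher from compound 1 to compound 2 (beyond the scatter) is modest in size and also concerns the loss or gain of 2,6-dichlorophenyl at this place. The group entering in compound 3 shares the 3-bromo label with the 3-bromo-4-fluorophenyl of compound 1, whose 14% is the nearest guide. Going by the values given here, no measured compound isolates the methoxy group, so this reading stays loose. A drop in this assay is therefore expected, of about the size of that one step or somewhat smaller. The expected change is a number 14 percentage points lower from compound 2 to compound 3 (beyond the scatter) as a working estimate. Compound 3 is estimated at 19% with an expected range from 5% to 36% for now.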

Compound 3, percent growth inhibition at one concentration: 41%
Compound 3: middle estimate off by 22 percentage points, on the low side; measured number outside the range, above it.
By their numbers in this assay, from the lowest: compound 1; then compounds 2 and 3 (each within the scatter of the next).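

With the bromo of the 3-bromo label common to both compounds, methoxy in place of fluoro on an aromatic carbon gives a number 27 percentage points higher from compound 1 to compound 3 (beyond the scatter) in this assay, so a bromo on this phenyl group does not by itself tie the series to a low number. The exchange of 2,6-dichlorophenyl for 3-bromo-4-methoxyphenyl on the saturated chain carbon gives a number 8 percentage points higher from compound 2 to compound 3 (within the scatter), so this assay does not separate these two groups, even though one has no hydrogen-bond acceptor and the other has one and no chlorine. The data at hand offer no explanation for either step.

The compounds shown leave open whether the methoxy group needs the bromo alongside it, a question that a 4-methoxyphenyl group without bromine would address. They also leave open how far the fluoro-to-methoxy step extends to other groups at that aromatic carbon, such as ethoxy, an amine or a carboxylic acid.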